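Compound 4: anilino replaces (oxolan-2-yl)methoxy

The compounds below may be only part of what the source reports. "The series", "measured", "known", "first", "only" and "open" are said of these compounds alone.

In an ADME assay on a cell-free system (plasma, Homo sapiens) for metabolic stability, read by LC-MS (a higher number here means that the compound lasts longer, a lower number that the compound disappears faster), compound 3 `NCc1ccc(C(=O)Nc2ccncc2F)cc1-c1cccc(C(=O)OCC2CCCO2)c1` gives < 0.0834 h, which is a limit of the assay and not a number. Compound 1 `CCCOC(=O)c1cccc(C(=O)Nc2cccc(-c3cc(C(=O)Nc4ccncc4F)ccc3CN)c2)c1` gives < 0.0834 h, also a limit. Compound 2 `NCc1ccc(C(=O)Nc2ccncc2F)cc1-c1cccc(NC(=O)c2cc(C(=O)O)ccc2F)c1` gives > 2 h, again a limit. Compound 1 and compound 3 are both esters, while compound 2 is not.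

Compound 4 `NCc1ccc(C(=O)Nc2ccncc2F)cc1-c1cccc(C(=O)Nc2ccccc2)c1` differs from compound 3 by a single change: anilino in place of (oxolan-2-yl)methoxy on a carbonyl carbon, with anilino in place of (oxolan-2-yl)methoxy on a carbonyl carbon. This change also removes the ester. Within the data shown here, the nearest guide is therefore the only measured step, an at least 23-fold higher number from compound 1 to compound 2 (1.37 log units; beyond the scatter), which is large and also leads away from an ester. Among the measured compounds shown here, no measured compound here carries anilino, which leaves the forecast uncertain.

A similarly large rise is expected, and the estimated step is an at least 29-fold higher number from compound 3 to compound 4 (1.47 log units; beyond the scatter). Compound 4 is estimated at 2.5 h, with an expected range from 1 h to 6 h, and the result may well come back only as a limit.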

Compound 4, half-life: > 2 h
Compound 4: no number, only a limit; the forecaster's own chance of this, stated with the estimate: 75%; the middle value lies beyond the limit too.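

Putting anilino in place of (oxolan-2-yl)methoxy on the carbonyl carbon turns an ester into an amide and gives, in this assay, an at least 23-fold higher number from compound 3 to compound 4 (1.37 log units; beyond the scatter). The earlier step away from an ester also brought in a carboxylic acid, whereas this one reaches the same limit with no acid present. Across the compounds shown, the two esters sit at one limit and the two non-esters at the other, with no compound going against this, and the true size of the step cannot be read: the limit of > 2 h in this assay, at which 2 of the 4 values shown sit.

Still open, as far as these compounds go, is whether the amide alone is enough or the phenyl ring of anilino also counts, which a plain amino or methylamino group on the same carbonyl carbon would help to separate. From the compounds shown here alone, how long compound 4 really lasts also stays open, its value being only a limit.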